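The compounds below may be only part of what the source reports. "The series", "measured", "known", "first", "only" and "open" are said of these compounds alone.

Three compounds share one core: an aromatic ketone carrying a hydroxy group, joined through a four-carbon chain to a benzoic acid. Compound 1 `CCCC(=O)c1ccc(OCCCCOc2cc(C(=O)O)ccc2OC)c(C)c1O` in an assay on HEK293 cells for positive allosteric modulation of metabotropic glutamate receptor 3 (Rattus norvegicus), read by thallium flux, with a stated time of 2.5 min (on this read-out lower numbers stand for smaller maximal responses and higher numbers for larger maximal responses), gives 64.2%. Compound 2 `COc1ccc(C(=O)O)cc1OCCCCOc1ccc(C(=O)C(C)C)c(O)c1C` gives 59.9%, and the change a number 4.3 percentage points lower from compound 1 to compound 2 (within the scatter) shows how little that swap mattered. Compound 3 `Cc1c(OCCCCOc2cccc(C(=O)O)c2)ccc(C(=O)CC(C)C)c1O` gives 69.9%; it carries the largest of the three numbers, yet compound 1 sits closest to it and compound 2 furthest, both inside the usual scatter, so no real order among them can be claimed.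

Compound 4 `COc1ccc(C(=O)O)cc1OCCCCOc1ccc(C(=O)CC(C)C)c(O)c1C` is reached from compound 3 by one change: methoxy in place of hydrogen on an aromatic carbon. Going by the values given here, no measured step makes exactly this change. Among the compounds with values here, the only step on record, from compound 1 to compound 2, concerns a different part of the molecule and was within the scatter. Compound 1 and compound 2, which already carry this methoxy group, give numbers close to that of compound 3. Therefore compound 4 is expected to show a change a number 3.9 percentage points lower from compound 3 to compound 4 (within the scatter) that stays within the scatter, with an estimated value of 66% and a range from 52% to 80%.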

Compound 4, largest response reached (reported as percent of maximum), in percent of the reference or control that the assay uses: 100%
Compound 4: the middle estimate sits 34 percentage points below what was measured; measured number above the stated range.
By their numbers in this assay, from the lowest: compounds 2, 1 and 3 (each within the scatter of the next); then compound 4.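

In this assay, methoxy in place of hydrogen on the aromatic carbon ortho to a large group and para to a carboxy group gives a number 30.1 percentage points higher from compound 3 to compound 4 (beyond the scatter), so this position can matter a great deal. The ketone side matters as well: isobutyl in place of isopropyl gives a number 40.1 percentage points higher from compound 2 to compound 4 (beyond the scatter), and methyl in place of hydrogen on the saturated chain gives a number 35.8 percentage points higher from compound 1 to compound 4 (beyond the scatter), although the earlier change on that carbonyl carbon stayed within the scatter. Among these compounds, only compound 4 carries both the methoxy and the isobutyl group, and the large gain appears only there.

No available evidence explains this gain. From the compounds shown here alone, it remains open whether an ethoxy group or a fluorine atom at the same aromatic carbon, or a longer chain on the carbonyl carbon, would give a similar response.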